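The compounds below may be only part of what the source reports. "The series", "measured", "known", "first", "only" and "open" are said of these compounds alone.

Compound 1 `O=C(CC1CCCC1)Nc1c(C(O)(C(F)(F)F)C(F)(F)F)ccc2ccccc12` gives 81 nM in an assay on LtK cells with ATP-sensitive inward rectifier potassium channel 11 (Homo sapiens) as the target; on this read-out lower numbers stand for an effect already at smaller amounts and higher numbers for an effect only at larger amounts of compound. Compound 2 `O=C(Nc1c(C(O)(C(F)(F)F)C(F)(F)F)ccc2ccccc12)c1ccc(OC(F)(F)F)cc1` in this assay reaches only a limit of the assay, > 10000 nM. Among the measured compounds shown here, the single measured step, an at least 120-fold higher number from compound 1 to compound 2 (2.09 log units; beyond the scatter), therefore shifted the number far toward an effect only at larger amounts. Compound 3 `O=C(Nc1c(C(O)(C(F)(F)F)C(F)(F)F)ccc2ccccc12)c1cccs1` differs from compound 2 by thiophen-2-yl in place of 4-(trifluoromethoxy)phenyl on a carbonyl carbon. For the measured compounds named here, because the only measured step that placed an aromatic ring on that carbonyl carbon ended at the limit of > 10000 nM in this assay, at which 1 of the 2 values shown sits, a similar outcome is expected for compound 3. Compound 3 is estimated at 7000 nM, ranging from 1500 nM to 30000 nM. The expected step is an at least 1.4-fold lower number from compound 2 to compound 3 (0.15 log units; that floor lies within the scatter).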

Compound 3, half-maximal effective concentration: 12 nM
Beside the measured number, compound 3's estimate is 580-fold (2.77 log units) above it; the whole stated range lies above it.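

In this assay, an aromatic ring on this carbonyl carbon can go with a low number, so the outcome depends on which ring sits there: thiophen-2-yl in place of 4-(trifluoromethoxy)phenyl gives an at least 830-fold lower number from compound 2 to compound 3 (2.92 log units; beyond the scatter). Thiophen-2-yl in place of cyclopentylmethyl gives a 6.8-fold lower number from compound 1 to compound 3 (0.83 log units; beyond the scatter). The first of these steps has only a floor, since compound 2 stands at a limit of the assay: the limit of > 10000 nM in this assay, at which 1 of the 3 values shown sits.

The compounds shown leave open whether the thiophene ring itself or the removal of the 4-(trifluoromethoxy)phenyl group accounts for the difference. A plain phenyl or a furan-2-yl on that carbonyl carbon would help separate the two.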